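Tetrazolyl in Place of Nitro on a Dicarboxylic Anilide

The source may report more compounds than this note shows. Statements on the series, on what has been measured and on what is new or still open speak of the compounds shown alone.

Measured compounds:
compound 1 `O=C(Nc1ccccc1)c1ccc(-c2nn[nH]n2)cc1` with 40 mg/kg in a functional assay on the whole organism (stomach) with Rattus norvegicus as the target; a lower number here means that less compound is needed, a higher number that more compound is needed for the effect;
compound 2 `O=C(O)c1cc(NC(=O)c2ccc([N+](=O)[O-])cc2)cc(C(=O)O)c1` with 61.1 mg/kg in this assay;
compound 3 `N#Cc1ccc(C(=O)Nc2cc(C(N)=O)cc(C(=O)O)c2)cc1` with 87.2 mg/kg in this assay.

Among these three, compound 2 stands second highest; its gaps to compound 3 and to compound 1 both fall within the scatter, so the three values are not separated.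

Compound 4 `O=C(O)c1cc(NC(=O)c2ccc(-c3nn[nH]n3)cc2)cc(C(=O)O)c1` differs from compound 2 by 2H-tetrazol-5-yl in place of nitro on an aromatic carbon. Compound 1 carries the same tetrazole on a simpler anilide and gives 40 mg/kg. Among the compounds with values here, since no measured pair isolates this change, the step from compound 2 to compound 4 is expected to stay within the scatter, if anything slightly downward, estimated as a 1.4-fold lower number from compound 2 to compound 4 (0.13 log units; within the scatter). Compound 4 is therefore estimated at 45 mg/kg, in the range 15 mg/kg to 140 mg/kg.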

Compound 4, dose for 50% inhibition: 8.2 mg/kg
For compound 4 the middle estimate is 5.5-fold (0.74 log units) above the measured one, and the stated range ends above it.
By their numbers in this assay, from the lowest: compound 4; then compounds 1, 2 and 3 (each within the scatter of the next, the first and the last beyond it).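

In this assay the aromatic carbon para to a large group proves sensitive to what it carries: 2H-tetrazol-5-yl in place of nitro gives a 7.5-fold lower number from compound 2 to compound 4 (0.87 log units; beyond the scatter) and so a clear separation. Within the data shown here, the earlier compounds stood within the scatter of one another and offered no pair differing in one place, so this is the first single change that can be read here. Nothing measured here accounts for the size of this step.

The compounds shown leave open whether the step would be the same on a core without the two carboxylic acids. They also leave open how an amine or a sulfonamide on this aromatic carbon would compare with 2H-tetrazol-5-yl.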